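This account rests on a few compounds, and the source may have more. Where it says the series, first, only, none or still open, it means among the compounds named here.

Measured in an ADME assay on THP-1 cells (Homo sapiens) for cytotoxicity; a lower number here means that less compound is tolerated, a higher number that more compound is tolerated:
compound 1 `COc1ccc(-n2cc(COc3ccc(/C=N/Nc4nc(-c5cc6cccc(OC)c6oc5=O)cs4)cc3)nn2)cc1` gives 34500 nM
compound 2 `COc1ccc(-n2cc(COc3ccc(/C=N/Nc4nc(-c5ccc([N+](=O)[O-])cc5)cs4)cc3)nn2)cc1` gives 37900 nM
compound 3 `COc1ccc(-c2csc(N/N=C/c3ccc(OCc4cn(-c5ccc(OC)cc5)nn4)cc3)n2)cc1` gives 39000 nM

The three measured compounds share one core and differ only in the group carried on the aryl ring attached to the thiazole. Their numbers in this assay are bunched closely together: compound 3 is not separable from compound 2 or from compound 1, since every gap among the three lies within the scatter of repeated measurements. Going by the values given here, the one single-point step that can be read directly, a 1.0-fold higher number from compound 2 to compound 3 (0.01 log units; within the scatter), therefore shows no change beyond the scatter, and the values of compound 1 and compound 2 likewise stand within the scatter of each other.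

Compound 4 `COc1ccc(-n2cc(COc3ccc(/C=N/Nc4nc(-c5ccc(C)cc5)cs4)cc3)nn2)cc1` is not yet measured. It differs from compound 3 in one place: methyl in place of methoxy on an aromatic carbon. Among the compounds with values here, the step from compound 2 to compound 3 is the only measured step that bears on this change, an exchange of one group on the same aryl ring, and it was within the scatter. On that basis a step of a 1.1-fold lower number from compound 3 to compound 4 (0.02 log units; within the scatter) is expected, that is, no movement beyond the scatter. Compound 4 is thus estimated at 37000 nM, with a range from 20000 nM to 70000 nM.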

Compound 4, half-maximal cytotoxic concentration: 40300 nM
Compound 4: the middle estimate sits 1.1-fold (0.04 log units) below what was measured, within the range that was stated.
By their numbers in this assay, from the lowest: compounds 1, 2, 3 and 4 (each within the scatter of the next).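

In this assay the exchange of 4-methoxyphenyl for 4-methylphenyl gives a 1.0-fold higher number from compound 3 to compound 4 (0.01 log units; within the scatter) and so stays within the scatter, even though this change takes away the oxygen and the one hydrogen-bond acceptor that methoxy carries. Methyl in place of nitro gives a 1.1-fold higher number from compound 2 to compound 4 (0.03 log units; within the scatter) and also stays within the scatter, so nitro, methoxy and methyl on this aromatic carbon, para to a large group, now form a set in which none of the listed exchanges separates the compounds. No measured evidence is available that accounts for this flat result.

The compounds shown leave open whether a group of another kind on this aromatic carbon, such as an amine, a carboxylic acid or a longer alkyl chain, would move the number beyond the scatter. They also leave open whether a change elsewhere on the shared core, for instance exchanging the methoxy on the ring attached to the triazole for a chlorine, would shift the tolerated concentration in this assay at all.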